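This account rests on a few compounds, and the source may have more. Where it says the series, first, only, none or still open, it means among the compounds named here.

Compound 1 `O=C1CS/C(=N/c2ccccc2)N1Cc1ccncc1`: 99500 nM
Compound 2 `O=C1/C(=C\c2ccc([N+](=O)[O-])cc2)S/C(=N/c2ccccc2)N1Cc1ccncc1`: 250000 nM

In an ADME assay on HEK293 cells (Homo sapiens) for cytotoxicity, read by MTT assay, with a stated time of 48 h (on this read-out lower numbers stand for stronger inhibition and higher numbers for weaker inhibition), compound 2 stands as the higher of the two numbers, at 250000 nM, beyond the scatter from compound 1. Compound 3 `COc1ccc(OC)c(/C=C2/S/C(=N/c3ccccc3)N(Cc3ccncc3)C2=O)c1` keeps the shared core and differs from compound 2 by 2,5-dimethoxyphenyl in place of 4-nitrophenyl on a double-bonded chain carbon bound to a double-bonded ring carbon. Among the measured compounds shown here, no measured pair shows this change, so the expected move in this assay is modest, a 1.6-fold lower number from compound 2 to compound 3 (0.19 log units; within the scatter), with none beyond the scatter. For compound 3 the estimated value is 160000 nM, expected to fall between 70000 nM and 350000 nM.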

Compound 3, half-maximal inhibitory concentration: 80100 nM
Compound 3: middle estimate off by 2.0-fold (0.30 log units), on the high side; the measured number falls inside the stated range.
By their numbers in this assay, from the lowest: compounds 3 and 1 (each within the scatter of the next); then compound 2.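

Among the compounds shown here, compound 2 and compound 3 form the first measured pair that isolates a change on a double-bonded chain carbon bound to a double-bonded ring carbon. In this assay, 2,5-dimethoxyphenyl in place of 4-nitrophenyl gives a 3.1-fold lower number from compound 2 to compound 3 (0.49 log units; beyond the scatter), so the read-out responds to the aryl group at this place. Nothing measured here accounts for the step.

Going by these compounds, it remains open whether the step follows the loss of 4-nitrophenyl or the gain of 2,5-dimethoxyphenyl. On these data alone, how an aryl group bearing an amine or a carboxylic acid would read at this place also remains open.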